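Trimming compound 3 back to a methoxy analog

The compounds below may be only part of what the source reports. "The series", "measured", "known", "first", "only" and "open" are said of these compounds alone.

Compound 1 `O=C1NC(=S)S/C1=C\C=C\c1ccccc1`: 81%
Compound 2 `COc1ccccc1COc1ccccc1/C=C/C=C1\SC(=S)NC1=O`: 98%
Compound 3 `O=C1NC(=S)S/C1=C\C=C\c1ccccc1OCc1ccncc1`: 62%

Within the data shown here, in a functional assay on DLD-1 cells (Homo sapiens), read by microscopy and crystal violet staining, with a stated time of 20 h, tested at 10 ug/mL (a higher number here means more inhibition at the concentration tested (going by the name of the read-out), a lower number less inhibition), compound 3 gives the lowest of the three numbers measured so far. Both steps that lead to it are beyond the scatter: the replacement of hydrogen on an aromatic carbon by (pyridin-4-yl)methoxy gives a number 19 percentage points lower from compound 1 to compound 3 (beyond the scatter), and the exchange of 2-methoxyphenyl for pyridin-4-yl on a saturated chain carbon bound to an oxygen on an aromatic ring gives a number 36 percentage points lower from compound 2 to compound 3 (beyond the scatter).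

Compound 4 `COc1ccccc1/C=C/C=C1\SC(=S)NC1=O` has not yet been measured. It differs from compound 3 in one place: hydrogen in place of pyridin-4-yl on a saturated chain carbon bound to an oxygen on an aromatic ring

Both measured steps bear on this change, since each shows that placing pyridin-4-yl, with or without its methoxy link, on this part of the core lowers the inhibition, and the larger of the two steps concerns the very position that is now emptied. Taking pyridin-4-yl away again is therefore expected to move the number of compound 4 upward in this assay, by a number 22 percentage points higher from compound 3 to compound 4 (beyond the scatter), because compound 2 reached 98% and compound 1 reached 81% without this group. The estimate for compound 4 is 84%, within 66% to 98%.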

Compound 4, a percentage reported as inhibition, at one concentration (the size of the read-out at that concentration, not a potency): 69%
Compound 4: middle estimate off by 15 percentage points, on the high side; measured number inside the range.
By their numbers in this assay, from the lowest: compounds 3 and 4 (each within the scatter of the next); then compound 1; then compound 2.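

In this assay cutting (pyridin-4-yl)methoxy back to methoxy gives a number 7 percentage points higher from compound 3 to compound 4 (within the scatter) and so shows that removing pyridin-4-yl from the saturated chain carbon does not by itself bring the number back toward those of compound 1 or compound 2. The group on that carbon still matters, since hydrogen in place of 2-methoxyphenyl gives a number 29 percentage points lower from compound 2 to compound 4 (beyond the scatter) and the high number of compound 2 therefore goes with the 2-methoxyphenyl group and not with the oxygen link alone. Even the plain methoxy on the aromatic carbon, set against hydrogen, gives a number 12 percentage points lower from compound 1 to compound 4 (beyond the scatter) and so joins compound 3 in lying under compound 1, a pattern that compound 2 goes against.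

Nothing available explains any of these differences.
Still open, as far as these compounds go, is whether plain phenyl on the saturated chain carbon would match 2-methoxyphenyl, or whether the methoxy on that outer ring is needed, and how a carboxylic acid or an amine on that ring, or a longer chain in place of the methoxy, would read in this assay at the same concentration.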